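Replacing an ether-linked amide by a carbon-linked amide

The compounds below may be only part of what the source reports. "The series", "measured", "known", "first", "only" and "open" are said of these compounds alone.

Measured compounds:
- compound 1, `CC(C)CCn1nc(-c2cccs2)c(O)c(C2=NS(=O)(=O)c3cc(OC(C)C(N)=O)ccc3N2)c1=O`, 0.217 h
- compound 2, `CC(C)CCn1nc(-c2cccs2)c(O)c(C2=NS(=O)(=O)c3cc(OC(C)(C)C(N)=O)ccc3N2)c1=O`, 0.35 h

Both were tested in an in vitro ADME assay on microsomes from liver (Homo sapiens) for metabolic stability, tested at 5 uM; a higher number here means that the compound lasts longer, a lower number that the compound disappears faster. Compound 1 gives 0.217 h, the lowest of the two numbers, while compound 2 gives 0.35 h; the step of a 1.6-fold higher number from compound 1 to compound 2 (0.21 log units; within the scatter) lies within the scatter, so the two cannot be ordered.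

Compound 3, `CC(C)CCn1nc(-c2cccs2)c(O)c(C2=NS(=O)(=O)c3cc(CCC(N)=O)ccc3N2)c1=O`, has not been measured. It differs from compound 1 by 2-carbamoylethyl in place of 1-carbamoylethoxy on an aromatic carbon, on an aromatic carbon of a six-membered aromatic ring of carbon only, part of a fused or bridged system of two rings. Within the data shown here, no measured step touches this change: the only step available, a 1.6-fold higher number from compound 1 to compound 2 (0.21 log units; within the scatter), alters the carbon next to the amide rather than the link to the ring, and it stayed within the scatter. The author therefore expects a step of a 1.2-fold higher number from compound 1 to compound 3 (0.06 log units; within the scatter) from compound 1 that does not go beyond the scatter. For compound 3 the estimate in this assay is 0.25 h, with a range from 0.1 h to 0.6 h.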

Compound 3, half-life: > 1 h
Compound 3: no number, only a limit (the forecaster's own chance of this, stated with the estimate: 5%); middle value at least 4.0-fold (0.60 log units) from the limit.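

The earlier step, at the carbon bound to the carbonyl, stayed within the scatter, but changing the link to the aromatic carbon does move the half-life in this assay: 2-carbamoylethyl in place of 1-carbamoylethoxy gives an at least 4.6-fold higher number from compound 1 to compound 3 (0.66 log units; beyond the scatter). The change also holds against the methylated ether, where 2-carbamoylethyl in place of 1-carbamoyl-1-methylethoxy gives an at least 2.8-fold higher number from compound 2 to compound 3 (0.45 log units; beyond the scatter). The value of compound 3 is a limit and not a number, so both steps have only a lower bound: the limit of > 1 h in this assay, at which 1 of the 3 values shown sits.

The compounds shown do not separate the loss of the ether oxygen from the loss of the methyl branch, which a 3-carbamoylpropyl chain or a branched carbon-linked amide could address. As far as these compounds go, it also remains open whether a carboxylic acid or an amine in place of the primary amide would fare the same on this carbon-linked chain.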